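A few compounds are considered here, and "the series" means these few. Any claim that something is new, unique, unknown or untested is made for them only; others in the source may bear on it.

Measured compounds in a functional assay on A-375 cells (Homo sapiens) for inhibition, read by CCK-8 assay, with a stated time of 72 h, tested at 8 uM; on this read-out higher numbers stand for more inhibition of growth at the one concentration tested and lower numbers for less inhibition of growth:

compound 1 `Nc1ccccc1NC(=O)/C=C/c1ccc(CSc2ccc(F)cc2)cc1`: compound 1 gives 24.6%
compound 2 `Nc1ccccc1NC(=O)/C=C/c1ccc(CSCCc2ccccc2)cc1`: compound 2 gives 37.4%
compound 3 `Nc1ccccc1NC(=O)c1ccc(CSCCc2ccccc2)cc1`: compound 3 gives 69.9%

Compound 3 stands highest of the three in this assay, and its gaps to compound 2 and to compound 1 are both beyond the scatter. Going by the values given here, how the core of compound 3 differs from the core of compound 2 is not broken down here; the two values show only that compound 3 sits well above compound 2.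

Compound 4 `Nc1ccccc1NC(=O)c1ccc(CSc2ccc(F)cc2)cc1` is not yet measured. It is separated from compound 3 by 4-fluorophenyl in place of phenethyl on a sulfur. The same change has been measured once, from compound 2 to compound 1, where it reads 4-fluorophenyl in place of phenethyl on a sulfur and gave a number 12.8 percentage points lower from compound 2 to compound 1 (beyond the scatter). The place of the change is the same in both pairs, so this is the same change, seen on the other core.

Among the compounds with values here, for compound 4 the step is expected to resemble that single earlier one, so that a number 12.9 percentage points lower from compound 3 to compound 4 (beyond the scatter) is estimated, resting on the one measured pair with a number 12.8 percentage points lower from compound 2 to compound 1 (beyond the scatter). Compound 4 is therefore expected to give about 57% in this assay, with a likely range from 42% to 70%.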

Compound 4, percent growth inhibition at one concentration: 54.3%
For compound 4 the middle estimate is 2.7 percentage points above the measured one; the measured number falls inside the stated range.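

In this assay, 4-fluorophenyl in place of phenethyl on a sulfur gives a number 15.6 percentage points lower from compound 3 to compound 4 (beyond the scatter), and the step holds its size when read on the two cores: the same change on two cores in this assay, a number 12.8 percentage points lower (beyond the scatter) from compound 2 to compound 1 and a number 15.6 percentage points lower (beyond the scatter) from compound 3 to compound 4, 2.8 percentage points apart, within the scatter of two such steps

Within these two pairs, the change therefore carries from the core of compound 2 to the core of compound 3 with no difference that can be told from the scatter. Going by these compounds alone, this rests on only two pairs, one replacement and a single concentration in one cell line, so it does not show that other groups on the sulfur, or other cores, would behave the same way, and it gives no reason for the lower numbers.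

The replacement alters both the chain and the fluorine at once, so the compounds shown leave open which of the two goes with the step; a plain phenyl or a 4-fluorophenethyl on the sulfur would separate them. Also open, as far as these compounds go, is how an amine or a carboxylic acid at the end of a longer chain on the sulfur would read on either core.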